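This account rests on a few compounds, and the source may have more. Where it says the series, first, only, none or still open, it means among the compounds named here.

Of the compounds shown here, three with a shared core have been tested in a functional assay on HT-29 cells (Homo sapiens) for inhibition, read by sulforhodamine B assay, with a stated time of 48 h; on this read-out higher numbers stand for weaker inhibition of growth and lower numbers for stronger inhibition of growth. Compound 1 `O=C(Nc1cccc(-n2cc(-c3ccncc3)c(-c3ccc(Cl)c(O)c3)n2)c1)Nc1ccc(Cl)c(Cl)c1` reaches only a limit of the assay, > 32500 nM. Compound 2 `COc1cc(-c2nn(-c3cccc(NC(=O)c4ccc(Cl)c(C(F)(F)F)c4)c3)cc2-c2ccncc2)ccc1Cl` likewise gives only a limit, > 32500 nM. Compound 3 `O=C(Nc1cccc(-n2cc(-c3ccncc3)c(-c3ccc(Cl)c(O)c3)n2)c1)Nc1cc(C(F)(F)F)cc(C(F)(F)F)c1` gives a number, 1870 nM. Compound 2 therefore stands not at a number but at a limit; two of the three rest at the limit of > 32500 nM in this assay, at which 2 of the 3 values shown sit. Compound 4 `COc1cc(-c2nn(-c3cccc(NC(=O)Nc4cccc(C(F)(F)F)c4)c3)cc2-c2ccncc2)ccc1Cl` differs from compound 2 in one place: (3-(trifluoromethyl)phenyl)amino in place of 4-chloro-3-(trifluoromethyl)phenyl on a carbonyl carbon Compound 3, which also carries an amino group on its carbonyl carbon, gives 1870 nM, so compound 4 is expected to move toward stronger inhibition of growth, by a step of about an at least 6.5-fold lower number from compound 2 to compound 4 (0.81 log units; beyond the scatter), beyond the scatter. Compound 4 is estimated at 5000 nM, between 1500 nM and 25000 nM.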

Compound 4, concentration for total growth inhibition: 1870 nM
Compound 4: the middle estimate sits 2.7-fold (0.43 log units) above what was measured; the range from low to high includes it.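

Among these compounds, this is the first step in this assay that shows the group on this carbonyl carbon matters: an at least 17-fold lower number from compound 2 to compound 4 (1.24 log units; beyond the scatter). The change does two things at once: it adds an amino nitrogen with its hydrogen-bond donor, and it removes the ring chlorine.

The compounds shown leave open which of the two carries the step; a (4-chloro-3-(trifluoromethyl)phenyl)amino group on the same carbonyl carbon would separate them. The true size of the step also stays open because compound 2 rests at a limit, not a number: the limit of > 32500 nM in this assay, at which 2 of the 4 values shown sit.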